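The source may hold more compounds than are shown below. What is called first, only, known or untested is meant among the compounds shown, and "the series" means these compounds.

In an ADME assay on GES1 cells (Homo sapiens) for cytotoxicity, read by MTT assay, with a stated time of 24 h (on this read-out higher numbers stand for lower toxicity in this test and lower numbers for higher toxicity in this test), compound 1 `O=c1[nH]cc(S(=O)(=O)Nc2ccccc2-c2cn(-c3ccccc3F)nn2)c(=O)[nH]1` gives only a limit, > 100000 nM. Going by the values given here, compound 2 `O=c1[nH]cc(S(=O)(=O)Nc2cccc(-c3cn(-c4ccccc4)nn3)c2)c(=O)[nH]1` gives 22500 nM in this assay, which is the only number in the set. The other value shown is a limit, (the limit of > 100000 nM in this assay, at which 1 of the 2 values shown sits). Compound 3 `Cc1ccccc1-n1cc(-c2cccc(NS(=O)(=O)c3c[nH]c(=O)[nH]c3=O)c2)nn1` differs from compound 2 by methyl in place of hydrogen on an aromatic carbon. Among the compounds with values here, no measured step of this kind exists to guide the expectation, so the step is expected to be small, a 1.1-fold lower number from compound 2 to compound 3 (0.05 log units; within the scatter), with no direction beyond the usual scatter. Compound 3 is thus estimated at 20000 nM, within a range of 7000 nM to 60000 nM.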

Compound 3, half-maximal cytotoxic concentration: 21500 nM
Beside the measured number, compound 3's estimate is 1.1-fold (0.03 log units) below it, within the range that was stated.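

In this assay, going by these compounds alone, the methyl on an aromatic carbon, ortho to a large group, is the first change in one place that can be read, and it comes out as a 1.0-fold lower number from compound 2 to compound 3 (0.02 log units; within the scatter) for this pair. Phenyl to 2-methylphenyl therefore leaves the read-out within the scatter here, and nothing measured in this set bears on why. The compounds shown leave open whether an amine, a carboxylic acid or a methoxy group on that same carbon would also stay within the scatter.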